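The source may report more compounds than this note shows. Statements on the series, on what has been measured and on what is new or still open speak of the compounds shown alone.

Measured compounds in the series:
compound 1, `Cc1cc(CCC#N)cc(C)c1Oc1cc(Nc2ccc(C#N)cc2)c(N)cc1C(=O)N(C)C`, 1.65 h
compound 2, `Cc1cc(CCC#N)cc(C)c1Oc1cc(Nc2ccc(C#N)cc2)c(N)cc1CN(C)C`, 3.85 h

Within the data shown here, in an ADME assay on liver for metabolic stability, with Liver microsome (Homo sapiens) as the target, read by LC-MS, using microsomes, tested at 1 uM (on this read-out lower numbers stand for a shorter-lived compound and higher numbers for a longer-lived compound), compound 2 gives 3.85 h, the higher of the two numbers measured so far; the only comparison is a 2.3-fold higher number from compound 1 to compound 2 (0.37 log units; beyond the scatter), a change of dimethylcarbamoyl to (dimethylamino)methyl on an aromatic carbon of the shared core.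

Compound 3, `Cc1cc(CCC#N)cc(C)c1Oc1cc(Nc2ccc(C#N)cc2)c(N)cc1COC(=O)C1CC1`, has not been measured in this assay. Relative to compound 2 it carries (cyclopropylcarbonyl)oxy in place of dimethylamino on a saturated chain carbon bound to an aromatic carbon. Among the measured compounds shown here, the one measured step, a 2.3-fold higher number from compound 1 to compound 2 (0.37 log units; beyond the scatter), concerns the same position of the core but swaps groups of a different kind, so it bears on the question only loosely: it shows that a change at this place can move the half-life by a modest amount, without saying which way a replacement of the dimethylamino by (cyclopropylcarbonyl)oxy would go. For the measured compounds named here, no pair among the measured compounds contains an ester of this sort, so the direction rests on judgement rather than data. A modest step is expected, a 2.4-fold lower number from compound 2 to compound 3 (0.38 log units; beyond the scatter), with the estimate for compound 3 set at 1.6 h and a range from 0.5 h to 5 h.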

Compound 3, half-life: 0.195 h
Beside the measured number, compound 3's estimate is 8.2-fold (0.91 log units) above it; measured number outside the range, below it.
By their numbers in this assay, from the lowest: compound 3; then compound 1; then compound 2.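

In this assay, among these compounds, this position proves far more sensitive than the earlier pair could show: (cyclopropylcarbonyl)oxy in place of dimethylamino on a saturated chain carbon bound to an aromatic carbon gives a 20-fold lower number from compound 2 to compound 3 (1.30 log units; beyond the scatter) and is a large step, where the only earlier change at this place was modest. Measured against the dimethylcarbamoyl compound, ((cyclopropylcarbonyl)oxy)methyl gives an 8.5-fold lower number from compound 1 to compound 3 (0.93 log units; beyond the scatter) and so places compound 3 lowest of the three, with both of its steps beyond the scatter. No available evidence accounts for this drop in half-life.

Still open, from the compounds shown here alone, is whether the drop goes with the whole (cyclopropylcarbonyl)oxy group or with its three-membered ring, a question that an acetoxy group or a methoxy group on the same saturated chain carbon would help to settle. Also open, going by these compounds, is whether an amine other than dimethylamino, such as pyrrolidine or morpholine, would hold or extend the half-life of compound 2 at this place.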